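Moving the Carboxylate Across Two Cores

A few compounds are considered here, and "the series" means these few. Any claim that something is new, unique, unknown or untested is made for them only; others in the source may bear on it.

The measured compounds are:

Compound 1, `CN(Cc1cccc(C(=O)O)c1)c1ccc(OCc2c(-c3c(Cl)cccc3Cl)noc2C2CC2)nc1C(F)(F)F`, which in an assay on isolated protein for agonist activity at Bile acid receptor (Homo sapiens), read by FRET (a lower number here means that less compound is needed, a higher number that more compound is needed for the effect), gives 3 nM.
Compound 2, `CN(Cc1ccc(C(=O)O)cc1)c1ccc(OCc2c(-c3c(Cl)cccc3Cl)noc2C2CC2)nc1C(F)(F)F`, which in this assay gives 12 nM.
Compound 3, `CC(C)c1onc(-c2c(Cl)cccc2Cl)c1COc1cnc(N(C)Cc2ccc(C(=O)O)cc2)c(Cl)c1`, which in this assay gives 242 nM.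

Compound 1 and compound 2 share one core and differ only in the change (3-carboxyphenyl in place of 4-carboxyphenyl on a saturated chain carbon bound to a nitrogen on an aromatic ring). This change gave a 4.0-fold lower number from compound 2 to compound 1 (0.60 log units; beyond the scatter). Compound 3 carries a different core, and the difference between the two cores is not broken down here; what the values show is that compound 3 stands well above compound 2 and compound 1 in this assay.

Compound 4, `CC(C)c1onc(-c2c(Cl)cccc2Cl)c1COc1cnc(N(C)Cc2cccc(C(=O)O)c2)c(Cl)c1`, has not yet been measured. It relates to compound 3 as compound 1 relates to compound 2: the change is 3-carboxyphenyl in place of 4-carboxyphenyl on a saturated chain carbon bound to a nitrogen on an aromatic ring, and the place of the change reads the same for both pairs, so it is the same change made on a second core.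

Whether the step carries over from one core to the other is not known from these three compounds. For the measured compounds named here, the only guide is the measured step from compound 2 to compound 1, and on that basis a step of similar size is expected, a 4.0-fold lower number from compound 3 to compound 4 (0.61 log units; beyond the scatter), for compound 4 in this assay. Compound 4 is therefore estimated at 60 nM, with a range from 20 nM to 200 nM to allow for the core being different from that of compound 1 and compound 2.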

Compound 4, half-maximal effective concentration: 190 nM
Compound 4: middle estimate off by 3.2-fold (0.50 log units), on the low side; measured number inside the range.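

On the second core, the same move from 4-carboxyphenyl to 3-carboxyphenyl gave in this assay a 1.3-fold lower number from compound 3 to compound 4 (0.11 log units; within the scatter), so the two placements of the carboxylic acid cannot be told apart on this core. The step seen on the core of compound 1 and compound 2 therefore did not carry over at its full size to the core of compound 3 and compound 4, and the two steps differ: the same change on two cores in this assay, a 4.0-fold lower number (0.60 log units; beyond the scatter) from compound 2 to compound 1 and a 1.3-fold lower number (0.11 log units; within the scatter) from compound 3 to compound 4, 3.1-fold (0.50 log units) apart, beyond the scatter of two such steps

This shows that, in these two pairs, the size of the step depends on the core, so a step measured on one core was not a reliable guide to the other; it does not show which part of the cores accounts for the gap, or how the change would behave on any third core.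

The compounds shown leave open whether the step would return on a core that keeps the trifluoromethyl group but carries an isopropyl group in place of the cyclopropyl group, or on one that keeps the cyclopropyl group but carries a chlorine in place of the trifluoromethyl group. They also leave open whether an amide or a tetrazole in place of the carboxylic acid would follow the same course on the two cores.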